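From Acetate to Methylcarbamate: What Compound 3 Might Show

A few compounds are considered here, and "the series" means these few. Any claim that something is new, unique, unknown or untested is made for them only; others in the source may bear on it.

Compound 1, `CNC(=O)OCc1c2c(n(C)c1COC(=O)NC)C(=O)C(C)=C(OC)C2=O`: 0.14 ug/mL
Compound 2, `CNC(=O)OCc1c2c(n(C)c1COC(C)=O)C(O)=C(C)C(=N)C2=O`: > 31 ug/mL

In a functional assay on SW1271 cells (Homo sapiens) for antiproliferative activity (a lower number here means a stronger inhibitor, a higher number a weaker inhibitor), compound 1 gives 0.14 ug/mL. Compound 2 gives only > 31 ug/mL, which is a limit of the assay and not a number. Compound 2 therefore stands at the limit of > 31 ug/mL in this assay, at which 1 of the 2 values shown sits. Compound 3, `CNC(=O)OCc1c2c(n(C)c1COC(=O)NC)C(O)=C(C)C(=N)C2=O`, differs from compound 2 by methylamino in place of methyl on a carbonyl carbon. Among the compounds with values here, no step between measured compounds isolates this change, so its weight cannot be read from the data. Compound 3 is expected to stay close to compound 2, with an at least 1.5-fold lower number from compound 2 to compound 3 (0.19 log units; that floor lies within the scatter) not beyond the scatter, and a limit rather than a number remains likely. The estimate for compound 3 is 20 ug/mL, between 3 ug/mL and 60 ug/mL.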

Compound 3, half-maximal inhibitory concentration: 7.9 ug/mL
For compound 3 the middle estimate is 2.5-fold (0.40 log units) above the measured one, within the range that was stated.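

In this assay, methylamino in place of methyl on a carbonyl carbon, which turns acetoxymethyl into ((methylcarbamoyl)oxy)methyl, gives an at least 3.9-fold lower number from compound 2 to compound 3 (0.59 log units; beyond the scatter). Within the data shown here, this is the first step that isolates this change, and it shows that this position can move the read-out on the shared core. Its size is only a floor, as the value for compound 2 is a limit of the assay and not a number: the limit of > 31 ug/mL in this assay, at which 1 of the 3 values shown sits.

From the compounds shown here alone, the true size of the step stays open. So does whether ethylamino or dimethylamino on the same carbonyl carbon would match methylamino.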